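Compound 4: chloro in place of methyl, estimate

The compounds below may be only part of what the source reports. "The series", "measured", "known", "first", "only" and "open" are said of these compounds alone.

Compound 3 `Cc1cc(C(=O)O)ccc1OC[C@H](C)COc1ccc(C(=O)CC(C)(C)C)c(O)c1C` gives 446 nM in an assay for positive allosteric modulation of metabotropic glutamate receptor 2 (Rattus norvegicus) (a lower number here means that less compound is needed, a higher number that more compound is needed for the effect), the highest of the three numbers measured. Compound 1 `Cc1c(OC[C@@H](C)COc2ccc(Cl)c(C(=O)O)c2)ccc(C(=O)CC(C)(C)C)c1O` gives 377 nM, and the step of a 1.2-fold higher number from compound 1 to compound 3 (0.07 log units; within the scatter), so these two stand together. Compound 2 `COc1cc(C(=O)O)ccc1OC[C@H](C)COc1ccc(C(=O)CC(C)(C)C)c(O)c1C` gives 28 nM; the step of a 16-fold higher number from compound 2 to compound 3 (1.20 log units; beyond the scatter) is the only large one in the set.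

Compound 4 `Cc1c(OC[C@@H](C)COc2ccc(C(=O)O)cc2Cl)ccc(C(=O)CC(C)(C)C)c1O` differs from compound 3 by chloro in place of methyl on an aromatic carbon. Neither measured step covers this exchange: the step from compound 2 to compound 3 concerns methoxy against methyl, and the step from compound 1 to compound 3 swaps the whole substitution pattern of that ring, with chloro at another place on it, and stays within the scatter. Compound 1, which carries a chloro on this ring, thus gave a number close to that of compound 3. No step beyond the scatter is therefore expected for a 1.1-fold lower number from compound 3 to compound 4 (0.05 log units; within the scatter). Compound 4 is estimated at 400 nM, with a range from 150 nM to 1100 nM.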

Compound 4, half-maximal effective concentration: 477 nM
The estimate for compound 4 lay 1.2-fold (0.08 log units) below the measured number; the range from low to high includes it.
By their numbers in this assay, from the lowest: compound 2; then compounds 1, 3 and 4 (each within the scatter of the next).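

In this assay, going by these compounds alone, the exchange of methyl for chloro ortho to a large group and meta to a carboxy group gives a 1.1-fold higher number from compound 3 to compound 4 (0.03 log units; within the scatter), the first direct reading of this change at this position, and the two groups are not told apart here. Methoxy at the same place remains separate from chloro as well as from methyl, with a 17-fold higher number from compound 2 to compound 4 (1.23 log units; beyond the scatter), so compound 2 stands apart from the three others. The two chloro-bearing ring patterns also stay together, with a 1.3-fold higher number from compound 1 to compound 4 (0.10 log units; within the scatter), so the 4-carboxy-2-chlorophenyl and 3-carboxy-4-chlorophenyl groups cannot be separated by this read-out.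

On these data alone, whether the low number of compound 2 is particular to methoxy, or is shared by ethoxy, hydroxyl or an amine at this place, remains open. No supporting data bear on this result.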